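The source may hold more compounds than are shown below. What is called first, only, known or untested is meant among the compounds shown, and "the series" means these compounds.

Compound 2 `CC(C)(C)C1=NN(c2ccc(Cl)cc2)C(c2ccc(Cl)cc2)C1` stands without a number in an assay on isolated protein for inhibition of protein kinase C zeta type (Homo sapiens), with a stated time of 4 min; a lower number here means a stronger inhibitor, a higher number a weaker inhibitor: the entry for compound 2 reads "not determined" (no result reported). Compound 3 `CC(C)(C)C1=NN(c2ccc(O)cc2)C(c2ccc(Cl)cc2)C1` is recorded the same way, as "not determined" (no result reported). Going by the values given here, compound 1 `CC(C)(C)C1=NN(c2ccc(F)cc2)C(c2ccc(O)cc2)C1` is the only member of the series with a figure; in this assay compound 1 gives 9400 nM. Compound 4 `CC(C)(C)C1=NN(c2ccc(Cl)cc2)C(c2ccc(O)c(F)c2)C1` remains to be measured. From compound 2 to compound 4 the change is 3-fluoro-4-hydroxyphenyl in place of 4-chlorophenyl on a saturated ring carbon. Among the compounds with values here, no measured pair matches this step, so its size and direction in this assay are open; compound 1, which also carries a hydroxyphenyl on the saturated ring carbon, is the nearest point of reference and sits in the weak range. For compound 4 in this assay the expected value is 6000 nM, with an estimated range from 1500 nM to 25000 nM.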

Compound 4, half-maximal inhibitory concentration: 3800 nM
Estimate against measurement, compound 4: 1.6-fold (0.20 log units) above; the range from low to high includes it.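

In this assay no new step can be read linking compound 4 to compound 1, compound 2 or compound 3. The compounds shown leave open the size and direction of the change from 4-chlorophenyl to 3-fluoro-4-hydroxyphenyl. No evidence bears on this result.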